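Swapping the amine on a corticotropin-releasing factor receptor ligand

The source may report more compounds than this note shows. Statements on the series, on what has been measured and on what is new or still open speak of the compounds shown alone.

Measured compounds:
- compound 1 `CCCCN(CC)Cc1c(C(F)(F)F)nc2n(-c3c(C)cc(C)cc3C)c(Cl)cn12`, which in an assay on cells for displacement of a labelled ligand from corticotropin-releasing factor receptor 1 (Homo sapiens), with a stated time of 100 min (on this read-out lower numbers stand for stronger inhibition and higher numbers for weaker inhibition), gives 78 nM
- compound 2 `CCCN(Cc1c(C(F)(F)F)nc2n(-c3c(C)cc(C)cc3C)c(Cl)cn12)CC1CCC1`, which in this assay gives 5.3 nM
- compound 3 `CCN(Cc1c(C(F)(F)F)nc2n(-c3c(C)cc(C)cc3C)c(Cl)cn12)CC1CCC1`, which in this assay gives 16 nM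

Compound 3 stands second highest of the three numbers; compound 2 is nearest, and compound 1 furthest. Compound 4 `Cc1cc(C)c(-n2c(Cl)cn3c(CN4CCCC4c4ccccc4)c(C(F)(F)F)nc23)c(C)c1` differs from compound 3 in one place: 2-phenylpyrrolidin-1-yl in place of (cyclobutylmethyl)(ethyl)amino on a saturated chain carbon bound to an aromatic carbon. Among the compounds with values here, no measured step covers this exact change. The steps that do exist all alter the groups on the same amine nitrogen: a 15-fold lower number from compound 1 to compound 2 (1.17 log units; beyond the scatter), a 4.9-fold lower number from compound 1 to compound 3 (0.69 log units; beyond the scatter) and a 3.0-fold higher number from compound 2 to compound 3 (0.48 log units; beyond the scatter). They show that changes at this amine move the numbers beyond the scatter, in both directions, with the larger substituents giving the lower numbers. The new group is larger still but of a different shape, so its effect cannot be read off directly. A modest step is expected, leaning toward a lower number, shown as a 1.6-fold lower number from compound 3 to compound 4 (0.20 log units; within the scatter). Compound 4 is therefore estimated at 10 nM, with a range from 3 nM to 40 nM.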

Compound 4, inhibition constant: > 7000 nM
Compound 4: only a limit was reported; the forecaster's own chance of this, stated with the estimate: 0%; middle value at least 700-fold (2.84 log units) from the limit.
By their numbers in this assay, from the lowest: compound 2; then compound 3; then compound 1. At a limit, above all of these: compound 4.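

The value of compound 4 is a limit of the assay, not a number: the limit of > 7000 nM in this assay, at which 1 of the 4 values shown sits. All three open-chain amines point the same way, with an at least 430-fold higher number from compound 3 to compound 4 (2.64 log units; beyond the scatter) and an at least 1300-fold higher number from compound 2 to compound 4 (3.12 log units; beyond the scatter) and an at least 89-fold higher number from compound 1 to compound 4 (1.95 log units; beyond the scatter) when 2-phenylpyrrolidin-1-yl comes in. The amine on this saturated chain carbon bound to an aromatic carbon therefore does more than fine-tune the number, and the earlier pattern of larger groups giving lower numbers does not extend to all groups, with compound 4 going against it.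

This single change both closes the nitrogen into a ring and brings in a phenyl ring, so the compounds shown cannot tell which of the two matters. Plain pyrrolidin-1-yl, without the phenyl, and open-chain benzyl(ethyl)amino would pull these two features apart.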